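This account rests on a few compounds, and the source may have more. Where it says the series, first, only, none or still open, it means among the compounds named here.

Measured compounds:
Compound 1, `COc1ccc2nccc(C3CN(C4CCCCN(Cc5cc6ccccc6[nH]5)C4)C(=O)O3)c2c1` — < 50200 nM
Compound 2, `COc1ccc2nccc(C3CN(C4CCN(Cc5ccc6ccccc6c5)CC4)C(=O)O3)c2c1` — 1260 nM

Of the compounds shown here, two sharing one core have been tested in an in vitro functional assay on RBL cells for antagonist activity at C-C chemokine receptor type 8 (Homo sapiens), read by FLIPR and calcium flux; a lower number here means a stronger inhibitor, a higher number a weaker inhibitor. For compound 1, `COc1ccc2nccc(C3CN(C4CCCCN(Cc5cc6ccccc6[nH]5)C4)C(=O)O3)c2c1`, the value < 50200 nM is a limit of this assay and not a number. For the measured compounds named here, compound 2, `COc1ccc2nccc(C3CN(C4CCN(Cc5ccc6ccccc6c5)CC4)C(=O)O3)c2c1`, gives 1260 nM in this assay, and it is the only proper number among the two values. The other value, that of compound 1, sits at a limit, as the limit of < 50200 nM in this assay, at which 1 of the 2 values shown sits, shows.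

The account now follows the step from compound 2 to compound 3, `COc1ccc2nccc(C3CN(C4CCN(Cc5ccc(C#N)cc5)CC4)C(=O)O3)c2c1`, which has not yet been measured in this assay. The change is 4-cyanophenyl in place of naphthalen-2-yl on a saturated chain carbon bound to an amine nitrogen in a ring. Cut one bond further out, the same difference reads (naphthalen-2-yl)methyl to 4-cyanobenzyl: one of the two six-membered aromatic rings of carbon only leaves, and a triple bond outside aromatic rings enters.

Going by the values given here, no step between measured compounds is known here, so nothing measured sets the size of this one. Compound 3 is expected to be a weaker inhibitor than compound 2 by a modest step, estimated as a 2.8-fold higher number from compound 2 to compound 3 (0.44 log units; beyond the scatter). The estimate for compound 3 in this assay is 3500 nM, expected to fall between 1000 nM and 15000 nM.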

Compound 3, half-maximal inhibitory concentration: 12600 nM
Beside the measured number, compound 3's estimate is 3.6-fold (0.56 log units) below it; measured number inside the range.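

In this assay, for the compounds shown here, the change from (naphthalen-2-yl)methyl to 4-cyanobenzyl gives the first measured step between compounds that differ in one place: a 10-fold higher number from compound 2 to compound 3 (1.00 log units; beyond the scatter). It shows that the group on a saturated chain carbon bound to an amine nitrogen in a ring matters to this inhibition: with 4-cyanophenyl in place of naphthalen-2-yl, compound 3 is clearly a weaker inhibitor, yet at 12600 nM compound 3 still gives a proper number and not a limit. Nothing among the data shown accounts for the size of this step.

One of the two six-membered aromatic rings of carbon only leaves and a nitrile enters in the same change, so the compounds shown leave open how much of the step belongs to each, a question that an unsubstituted benzyl group in the same place would help to separate. Also open, as far as these compounds go, is whether a second fused ring carrying a nitrile, or a 4-chlorobenzyl group, would stay nearer to compound 2 or to compound 3 in this assay.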